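This account rests on a few compounds, and the source may have more. Where it says the series, first, only, none or still open, it means among the compounds named here.

Three compounds share a measurement in a functional assay on CHO cells for agonist activity at Alpha-1A adrenergic receptor (Homo sapiens), read by FLIPR and calcium flux; a higher number here means a larger maximal response, a lower number a smaller maximal response. Compound 1, `Cc1c(OCC2=NCCN2)ccc(Cl)c1NS(C)(=O)=O`, gives 60%. Compound 2, `c1ccc2c(c1)CCC2c1ncc[nH]1`, gives 54%, the lower of the two single numbers, though compound 1 lies only a few points higher, within the scatter. Compound 3, `CS(=O)(=O)Nc1cccc2c1CCCC2c1ncc[nH]1`, has several entries and gives 47%; 79%; 79% (3 entries); the spread of those entries, (the several entries of compound 3 in this assay, 47%; 79%; 79% (3 entries)), shows how far repeated readings of one compound can drift.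

Compound 4, `c1cc(-c2cn[nH]c2)c2c(c1)C(c1ncc[nH]1)CC2`, has not yet been measured. It differs from compound 2 in one place: 1H-pyrazol-4-yl in place of hydrogen on an aromatic carbon. Among the measured compounds shown here, no measured pair shows what such a change does in this assay, so the direction is open. The expectation is that the step from compound 2 to compound 4 in this assay will be small, no further than the scatter, giving an estimated a number 1 percentage points higher from compound 2 to compound 4 (within the scatter). On that basis compound 4 is expected to reach about 55%, with a range from 30% to 80%.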

Compound 4, largest response reached (Emax), in percent of the reference or control that the assay uses: 84%
The estimate for compound 4 lay 29 percentage points below the measured number; the measured number lies above the stated range.
By their numbers in this assay, from the lowest: compounds 2 and 1 (each within the scatter of the next); then compound 4.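

Among the compounds shown here, until compound 4, no measured pair showed what any group on this aromatic carbon of the shared core does. In this assay, 1H-pyrazol-4-yl in place of hydrogen gives a number 30 percentage points higher from compound 2 to compound 4 (beyond the scatter), so at this position the group goes with a larger maximal response, not a smaller one. The step lies beyond the usual scatter, but this single pair should still be read with care, since repeated readings of one compound can differ by a similar amount: the several entries of compound 3 in this assay, 47%; 79%; 79% (3 entries).

One pair cannot tell whether this rise belongs to 1H-pyrazol-4-yl in particular or would follow from other groups on the same carbon. On these data alone, a phenyl ring or an amine there would help separate those two readings, and whether the rise carries over to the core of compound 3 also remains open.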